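A few compounds are considered here, and "the series" means these few. Any claim that something is new, unique, unknown or untested is made for them only; others in the source may bear on it.

Of the compounds shown here, three sharing one core have been measured in a functional assay (aorta) with Rattus norvegicus as the target; a lower number here means that less compound is needed, a higher number that more compound is needed for the effect. Compound 1 `COc1ccc(-c2nc(N=C(N)N)sc2-c2ccc(OC)cc2)cc1` gives 2 uM. Compound 2 `COc1ccc(-c2nc(/N=C(\N)[N+]3(C)CCCCC3)sc2-c2ccc(OC)cc2)cc1` gives 21 uM. Compound 3 `COc1ccc(-c2nc(CNC(=O)N3CCOCC3)sc2-c2ccc(OC)cc2)cc1` gives 12 uM, the second highest of the three numbers; its nearest neighbour is compound 2, and the step of a 1.8-fold lower number from compound 2 to compound 3 (0.24 log units; within the scatter) lies within the scatter, while the step of a 6.0-fold higher number from compound 1 to compound 3 (0.78 log units; beyond the scatter) lies beyond it.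

Compound 4 `CCOC(=O)/C=C/c1nc(-c2ccc(OC)cc2)c(-c2ccc(OC)cc2)s1` has not yet been measured in this assay. It differs from compound 3 in one place: 2-(ethoxycarbonyl)ethenyl in place of (((morpholin-4-yl)carbonyl)amino)methyl on an aromatic carbon. For the measured compounds named here, no measured step involves the entering group. The steps of an 11-fold higher number from compound 1 to compound 2 (1.02 log units; beyond the scatter) and a 6.0-fold higher number from compound 1 to compound 3 (0.78 log units; beyond the scatter) show that replacing the smaller group on that aromatic carbon with a larger one raised the number, and the step of a 1.8-fold lower number from compound 2 to compound 3 (0.24 log units; within the scatter) shows that two different larger groups there gave numbers within the scatter of each other. On that basis the step of a 1.3-fold higher number from compound 3 to compound 4 (0.10 log units; within the scatter) is expected to be small, with no clear direction beyond the scatter. Compound 4 is therefore estimated at 15 uM, within a range from 5 uM to 50 uM.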

Compound 4, concentration for half-maximal effect: > 100 uM
Compound 4: a limit, no number (the forecaster's own chance of this, stated with the estimate: 10%); middle value at least 6.6-fold (0.82 log units) from the limit.
By their numbers in this assay, from the lowest: compound 1; then compounds 3 and 2 (each within the scatter of the next). At a limit, above all of these: compound 4.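

The steps of an at least 8.3-fold higher number from compound 3 to compound 4 (0.92 log units; beyond the scatter), an at least 4.7-fold higher number from compound 2 to compound 4 (0.67 log units; beyond the scatter) and an at least 50-fold higher number from compound 1 to compound 4 (1.69 log units; beyond the scatter) show that this aromatic carbon does not accept every group larger than that of compound 1 equally. Size alone no longer orders the series: 2-(ethoxycarbonyl)ethenyl has fewer heavy atoms than the groups of compound 2 and compound 3, yet compound 4 stands above both, so these two compounds go against any rule that a larger group gives a higher number. The result for compound 4 is a limit of the assay, not a number: the limit of > 100 uM in this assay, at which 1 of the 4 values shown sits.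

Going by these compounds, how far compound 4 really lies above the others stays unknown. The compounds shown also leave open whether the ethyl ester or the double bond matters, which a carboxylic acid or a saturated chain at this carbon could begin to separate.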